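Thiazolyl hydrazone series: aryl swap on the thiazole

A few compounds are considered here, and "the series" means these few. Any claim that something is new, unique, unknown or untested is made for them only; others in the source may bear on it.

Measured so far:
compound 1 `COc1cc(/C=N/Nc2nc(-c3ccc(Br)cc3)cs2)cc(Br)c1OC` — 52300 nM
compound 2 `COc1cc(/C=N/Nc2nc(-c3ccccc3)cs2)c(Br)c(Br)c1OC` — 15300 nM
compound 3 `COc1ccccc1-c1csc(N/N=C/c2cc(OC)c(OC)c(Br)c2Br)n1` — 85100 nM

In a functional assay on A549 cells (Homo sapiens) for inhibition, read by MTT assay, with a stated time of 48 h (on this read-out lower numbers stand for stronger inhibition and higher numbers for weaker inhibition), compound 3 gives 85100 nM, the highest of the three numbers; compound 1 gives 52300 nM, within the scatter of it, while compound 2 gives 15300 nM. Compound 4 `COc1cc(/C=N/Nc2nc(-c3ccc(Br)cc3)cs2)c(Br)c(Br)c1OC` differs from compound 3 by 4-bromophenyl in place of 2-methoxyphenyl on an aromatic carbon. Among the measured compounds shown here, the one measured step bearing on this part is a 5.6-fold higher number from compound 2 to compound 3 (0.75 log units; beyond the scatter); the present change also removes that methoxy, so a move back toward compound 2 is expected. Compound 1, which carries the same 4-bromophenyl with another substitution pattern elsewhere, gives 52300 nM. For the measured compounds named here, the bromine's own contribution has no measured step. Compound 4 is therefore expected at 25000 nM, range 8000 nM to 80000 nM. The expected step is a 3.4-fold lower number from compound 3 to compound 4 (0.53 log units; beyond the scatter).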

Compound 4, half-maximal inhibitory concentration: 46100 nM
Beside the measured number, compound 4's estimate is 1.8-fold (0.27 log units) below it; measured number inside the range.
By their numbers in this assay, from the lowest: compound 2; then compounds 4, 1 and 3 (each within the scatter of the next).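

Read in this assay the exchange of 2-methoxyphenyl for 4-bromophenyl at this aromatic carbon gives a 1.8-fold lower number from compound 3 to compound 4 (0.27 log units; within the scatter) and so does not separate the two aryl groups. Bromo in place of hydrogen on the phenyl gives a 3.0-fold higher number from compound 2 to compound 4 (0.48 log units; beyond the scatter) and runs the same way as the methoxy step a 5.6-fold higher number from compound 2 to compound 3 (0.75 log units; beyond the scatter), while bromo in place of hydrogen on the ring bearing the two methoxy groups gives a 1.1-fold lower number from compound 1 to compound 4 (0.05 log units; within the scatter) and leaves the number within the scatter. No data at hand explain these steps.

Open, from the compounds shown here alone, is how an amine, a carboxylic acid or a longer alkoxy chain on this phenyl would compare with bromo and methoxy.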